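The source may hold more compounds than are shown below. What is called first, only, known or untested is meant among the compounds shown, and "the series" means these compounds.

Of the compounds shown here, three have been measured in a functional assay on SW-620 cells (Homo sapiens) for cytotoxicity, read by sulforhodamine B assay, with a stated time of 48 h; a lower number here means a stronger inhibitor of growth, a higher number a weaker inhibitor of growth. Compound 1 `ClCc1ccccc1Cn1cnc2c(Cl)nc(Cl)nc21` gives 150 nM. Compound 2 `ClCc1ccccc1Cn1cnc2c(Cl)ncnc21` gives 1770 nM. Compound 3 `ClCc1cccc(Cn2cnc3ncnc(Cl)c32)c1` gives 15100 nM, the highest of the three numbers.

Compound 1 and compound 2 differ in one place, by chloro in place of hydrogen on an aromatic carbon, and that change gave a 12-fold lower number from compound 2 to compound 1 (1.07 log units; beyond the scatter). Compound 2 and compound 3 share the same atoms joined differently; the difference between the two cores is not broken down here, and their values alone show that compound 3 sits well above compound 2 in this assay.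

Compound 4 `ClCc1cccc(Cn2cnc3nc(Cl)nc(Cl)c32)c1` has not yet been measured. It differs from compound 3 by chloro in place of hydrogen on an aromatic carbon, the same change in the same surroundings that turned compound 2 into compound 1. Because that change gave a 12-fold lower number from compound 2 to compound 1 (1.07 log units; beyond the scatter), a step of a similar size is expected here, with some allowance for a different core, so the expected step is a 10-fold lower number from compound 3 to compound 4 (1.00 log units; beyond the scatter). Compound 4 is therefore estimated at 1500 nM, with a likely range from 500 nM to 5000 nM.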

Compound 4, concentration for 50% growth inhibition: 410 nM
Beside the measured number, compound 4's estimate is 3.7-fold (0.56 log units) above it; the whole stated range lies above it.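

In this assay, placing a chloro group on the aromatic carbon between two ring nitrogen atoms lowered the number on both cores, and on the second core the result was a 37-fold lower number from compound 3 to compound 4 (1.57 log units; beyond the scatter). The direction of the change therefore carried over from one core to the other, but its size did not stay the same: the same change on two cores in this assay, a 12-fold lower number (1.07 log units; beyond the scatter) from compound 2 to compound 1 and a 37-fold lower number (1.57 log units; beyond the scatter) from compound 3 to compound 4, 3.1-fold (0.49 log units) apart, beyond the scatter of two such steps

Two cores are only two cases, so these results cannot show how large the step would be on a further core, and the numbers alone do not explain why its size differs between these two.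

The compounds shown carry only hydrogen or chloro at this place, so it remains open whether another group there, such as an amine, a methoxy group or a nitrile, would also lower the number. As far as these compounds go, it also remains open whether the chloro step would keep its direction and size if the chloromethyl group were replaced by a plain methyl group.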